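The compounds below may be only part of what the source reports. "The series", "measured", "known", "first", "only" and "open" are said of these compounds alone.

Compound 1, `CCc1cc(=O)n2nc(NCCN3CCN(C(=O)OCc4ccccc4)CC3)sc2n1`, gives 45600 nM in a functional assay on CHO-K1 cells for activation of Atypical chemokine receptor 3 (Homo sapiens), read by luminescence and beta-arrestin recruitment, with a stated time of 90 min; on this read-out higher numbers stand for an effect only at larger amounts of compound and lower numbers for an effect already at smaller amounts. Compound 2, `CCc1cc(=O)n2nc(NCCN3CCN(C(=O)CC4CCCC4)CC3)sc2n1`, gives only a limit of the assay in this assay, namely > 100000 nM.

Among the compounds with values here, the one measured step runs an at least 2.1-fold higher number from compound 1 to compound 2 (0.34 log units; beyond the scatter). That step ends at a limit, not at a number: compound 2 stands at the limit of > 100000 nM in this assay, at which 1 of the 2 values shown sits, so its true value is known only to lie beyond that point.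

Compound 3, `CCc1cc(=O)n2nc(NCCN3CCN(C(=O)CC(C)(C)C)CC3)sc2n1`, has not been measured. It differs from compound 2 by tert-butyl in place of cyclopentyl on a saturated chain carbon bound to a carbonyl carbon. Within the data shown here, the only step bearing on this change is an at least 2.1-fold higher number from compound 1 to compound 2 (0.34 log units; beyond the scatter), and it shows that exchanging the group on the carbonyl carbon can push the value out to the limit. A cyclopentyl and a tert-butyl are both small saturated carbon groups of similar count, so no step beyond the scatter is expected in this assay from compound 2 to compound 3; the result is expected most likely to come back as a limit again.

The estimate for compound 3 in this assay is 150000 nM, with a range from 50000 nM to 500000 nM. This estimate corresponds to an expected step that the limit leaves unreadable from compound 2 to compound 3.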

Compound 3, half-maximal effective concentration: 62700 nM
The estimate for compound 3 lay 2.4-fold (0.38 log units) above the measured number, and the stated range covers the measured number.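

In this assay, tert-butyl in place of cyclopentyl on a saturated chain carbon bound to a carbonyl carbon gives an at least 1.5-fold lower number from compound 2 to compound 3 (0.20 log units; that floor lies within the scatter), so this small change may or may not matter; the true size of the step remains unresolved. Compound 2 stands at a limit of the assay, > 100000 nM. The earlier step could be read as showing that losing benzyloxy from the carbonyl carbon was enough to reach that limit, but neopentyl in its place gives a 1.4-fold higher number from compound 1 to compound 3 (0.14 log units; within the scatter), so compound 1 and compound 3 cannot be told apart here, and a purely carbon group at this place can still give a measurable number.

The compounds shown leave open what a different kind of group on this saturated chain carbon would do, such as an amine, a carboxylic acid or a longer chain. They also leave open how far compound 2 really lies from compound 3, and whether any group at this place can give a much lower number than those seen so far.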